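Changing the amide group in a CDK8 binding series

The compounds below may be only part of what the source reports. "The series", "measured", "known", "first", "only" and "open" are said of these compounds alone.

Compound 1 `CNC(=O)/C=C/c1ccncc1-c1ccc2ccccc2c1` gives 101% in an assay on a protein complex for inhibition of CDK8/Cyclin C (Homo sapiens), with a stated time of 1 h, tested at 10 uM; on this read-out lower numbers stand for less inhibition and higher numbers for more inhibition at the one concentration tested (going by the name of the read-out). Going by the values given here, compound 2 `CC(C)[C@@H](NC(=O)/C=C/c1ccncc1-c1ccc2ccccc2c1)C(=O)O` gives 77% in this assay, the lower of the two numbers measured so far. Compound 3 `O=C(/C=C/c1ccncc1-c1ccc2ccccc2c1)N1CCOCC1` carries the change (morpholin-4-yl in place of (1-carboxy-2-methylpropyl)amino on a carbonyl carbon). Among the compounds with values here, the only measured step that bears on it is a number 24 percentage points lower from compound 1 to compound 2 (beyond the scatter), which likewise altered the group on the amide nitrogen. Because that step was a number 24 percentage points lower from compound 1 to compound 2 (beyond the scatter), a smaller cyclic group is expected to give back part of it, an expected step of a number 13 percentage points higher from compound 2 to compound 3 (beyond the scatter). Compound 3 is therefore estimated at 90%, between 70% and 103%.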

Compound 3, a percentage reported as inhibition, at one concentration (the size of the read-out at that concentration, not a potency): 99%
Beside the measured number, compound 3's estimate is 9 percentage points below it; low and high end bracket the measured number.
By their numbers in this assay, from the lowest: compound 2; then compounds 3 and 1 (each within the scatter of the next).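

In this assay, the change gives a number 22 percentage points higher from compound 2 to compound 3 (beyond the scatter), so morpholin-4-yl on this carbonyl carbon restores what (1-carboxy-2-methylpropyl)amino lost. Measured against methylamino, the same group gives a number 2 percentage points lower from compound 1 to compound 3 (within the scatter), which shows that this position accepts a six-membered ring without a clear change in the number. Nothing measured here explains the difference between these groups. As far as these compounds go, it remains open whether the lower number of compound 2 goes with its carboxylic acid or with its branched chain. A methyl ester or a piperazin-1-yl group could help to test this.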